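The compounds below may be only part of what the source reports. "The series", "measured", "known", "first", "only" and "open" are said of these compounds alone.

Compound 1 `CCc1ccc(S(=O)(=O)NC(=O)Nc2ccc(Cl)cc2)s1` gives 89%
Compound 2 `CCCc1ccc(S(=O)(=O)NC(=O)Nc2ccc(Cl)cc2)s1` gives 39%
Compound 3 `Cc1ccsc1S(=O)(=O)NC(=O)Nc1ccc(Cl)cc1` gives 62%

All three values come from a functional assay on the whole organism (6C3HED cells, Mus musculus) for inhibition, at a dose of 300 mg/kg by the oral route; a higher number here means more inhibition at the dose given (going by the name of the read-out), a lower number less inhibition. Compound 2 differs from compound 1 by methyl in place of hydrogen on a saturated chain carbon, two bonds along the chain from an aromatic carbon, and this gave a number 50 percentage points lower from compound 1 to compound 2 (beyond the scatter). Compound 3 carries a different core, (3-methylthiophen-2-yl in place of 5-ethylthiophen-2-yl on a sulfonyl sulfur), which gave a number 27 percentage points lower from compound 1 to compound 3 (beyond the scatter). Compound 4, `CCc1ccsc1S(=O)(=O)NC(=O)Nc1ccc(Cl)cc1`, has not yet been measured in this assay. It differs from compound 3 by methyl in place of hydrogen on a saturated chain carbon bound to an aromatic carbon. This is the same kind of change as from compound 1 to compound 2, though the place is not identical: there the carbon stood two bonds along the chain from an aromatic carbon, here it is bound to an aromatic carbon. A drop is expected for compound 4 because a number 50 percentage points lower from compound 1 to compound 2 (beyond the scatter) showed a large loss for the same kind of change, so the expected step is a number 32 percentage points lower from compound 3 to compound 4 (beyond the scatter). Compound 4 is therefore estimated at 30%, between 10% and 55%.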

Compound 4, a percentage reported as inhibition, in the whole organism at one dose (the size of the read-out at that dose, not a potency): 25%
For compound 4 the middle estimate is 5 percentage points above the measured one, and the stated range covers the measured number.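

In this assay, methyl in place of hydrogen gave a number 37 percentage points lower from compound 3 to compound 4 (beyond the scatter), and the same change on the two cores compares as follows: the same change on two cores in this assay, a number 50 percentage points lower (beyond the scatter) from compound 1 to compound 2 and a number 37 percentage points lower (beyond the scatter) from compound 3 to compound 4, 13 percentage points apart, within the scatter of two such steps. Across these two pairs, the change carries from one core to the other with a clear loss each time, even though the carbon that takes the methyl is not the same place on the chain. This says nothing about other cores or about why the number falls, and 3-ethylthiophen-2-yl in place of 5-ethylthiophen-2-yl is a separate change, which gave a number 64 percentage points lower from compound 1 to compound 4 (beyond the scatter).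

As far as these compounds go, whether a longer chain such as butyl would continue the fall on either core stays open. So does the effect of an amine or a carboxylic acid at the end of the chain.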